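A Longer Tail on the Core of Compound 2

The source may report more compounds than this note shows. Statements on the series, on what has been measured and on what is new or still open speak of the compounds shown alone.

Compound 2 `CN(C)c1c(F)c(N)c2c(=O)cc(-c3ccc(N)c(F)c3)oc2c1F` gives 39 nM in a functional assay on MCF7 cells (Homo sapiens) for cytotoxicity, read by neutral red uptake, with a stated time of 3 days (a higher number here means a weaker inhibitor, a lower number a stronger inhibitor), the lowest of the two numbers measured here. Compound 1 `CCc1c(F)c(N)c2c(=O)cc(-c3ccc(N)c(F)c3)oc2c1F`, with ethyl in that place, gives 130 nM, so exchanging ethyl for dimethylamino brought a 3.3-fold lower number from compound 1 to compound 2 (0.52 log units; beyond the scatter). Compound 3 `CCCCCCCCCCCCCCCCCC(=O)OCc1c(F)c(N)c2c(=O)cc(-c3ccc(N)c(F)c3)oc2c1F` carries a long ester chain on the same carbon, and in this assay compound 3 reaches only a limit, > 10000 nM. That value is the limit of > 10000 nM in this assay, at which 1 of the 3 values shown sits. Compound 4 `CN(C)CCCOCc1c(F)c(N)c2c(=O)cc(-c3ccc(N)c(F)c3)oc2c1F` differs from compound 2 by (3-(dimethylamino)propoxy)methyl in place of dimethylamino on an aromatic carbon. Among the measured compounds shown here, the one measured step at this carbon, a 3.3-fold lower number from compound 1 to compound 2 (0.52 log units; beyond the scatter), was modest, and a long chain there is linked with a limit, so a loss is expected rather than a gain. Compound 4 is therefore expected to give 300 nM, within 60 nM to 3000 nM, an estimated 7.7-fold higher number from compound 2 to compound 4 (0.89 log units; beyond the scatter).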

Compound 4, half-maximal inhibitory concentration: > 10000 nM
Compound 4 was reported as a limit; the forecaster's own chance of this, stated with the estimate: 15%; middle value at least 33-fold (1.52 log units) from the limit.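

Putting (3-(dimethylamino)propoxy)methyl on this aromatic carbon gives an at least 250-fold higher number from compound 2 to compound 4 (2.40 log units; beyond the scatter), and the other comparison gives an at least 76-fold higher number from compound 1 to compound 4 (1.88 log units; beyond the scatter); both steps are minimum sizes, set by a limit of the assay. Loss of activity with a long chain at this carbon is thus no longer tied to the ester alone, since compound 3 and compound 4 both stand at a limit: the limit of > 10000 nM in this assay, at which 2 of the 4 values shown sit.

The compounds shown leave open how long a chain this carbon accepts, which a propyl or methoxymethyl group could help settle. They also leave open whether a chain ending in a carboxylic acid would fare differently.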